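Propanoyl for propyl on the shared core

The source may hold more compounds than are shown below. What is called first, only, known or untested is meant among the compounds shown, and "the series" means these compounds.

Compound 1 `CCCc1ccc2c(c1)sc(=O)n2CCN1CCCCCC1` gives 1.6 nM in an assay on cell membranes for displacement of a labelled ligand from Sigma non-opioid intracellular receptor 1 (Rattus norvegicus) (on this read-out higher numbers stand for weaker inhibition and lower numbers for stronger inhibition), the lowest of the three numbers in hand. Compound 2 `O=c1sc2ccccc2n1CCCN1CCCCCC1` gives 4.1 nM in this assay, and compound 3 `O=c1sc2ccccc2n1CCCCCN1CCCCCC1` gives 7 nM in this assay; both stand beyond the scatter from compound 1, compound 2 the nearer and compound 3 the further. Going by the values given here, no two of the measured compounds differ in a single place, so no measured step is available. Compound 4 `CCC(=O)c1ccc2c(c1)sc(=O)n2CCN1CCCCCC1` differs from compound 1 by propanoyl in place of propyl on an aromatic carbon. Among the compounds with values here, with no step of this kind measured, the expectation is a modest move toward a higher number, about a 3.1-fold higher number from compound 1 to compound 4 (0.49 log units; beyond the scatter), beyond the scatter but not by much. Compound 4 is therefore expected to give around 5 nM in this assay, within 1.5 nM to 16 nM.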

Compound 4, inhibition constant: 4.5 nM
Compound 4: middle estimate off by 1.1-fold (0.05 log units), on the high side; the measured number falls inside the stated range.
By their numbers in this assay, from the lowest: compound 1; then compounds 2, 4 and 3 (each within the scatter of the next).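

Going by these compounds alone, this is the first measured step at this position: propanoyl in place of propyl on an aromatic carbon gives a 2.8-fold higher number from compound 1 to compound 4 (0.45 log units; beyond the scatter) in this assay and so moves the number only modestly. The position accepts a carbonyl and its hydrogen-bond acceptor with affinity retained, as compound 4 gives 4.5 nM in this read-out. Nothing measured here gives a reason for the step.

Within the data shown here, it remains open whether the carbonyl or the chain drives the step, since only one pair is available. On these data alone, how an amine, a carboxylic acid or a longer chain would read on this aromatic carbon also remains open.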